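The compounds below may be only part of what the source reports. "The series", "measured", "known", "first", "only" and "open" are said of these compounds alone.

- compound 1 `COc1ccc(-c2nnc(NC(=O)/C=C/c3ccc(C)cc3)s2)cc1`: 0.58 ug/mL
- compound 2 `Cc1ccc(/C=C/C(=O)Nc2nnc(-c3ccccc3)s2)cc1`: 1.58 ug/mL
- compound 3 `COc1ccc(-c2nnc(NC(=O)/C=C/c3ccccc3)s2)cc1`: not yet measured

Within the data shown here, in a functional assay on A549 cells (Homo sapiens) for antiproliferative activity, read by MTT assay, with a stated time of 48 h (on this read-out lower numbers stand for stronger inhibition and higher numbers for weaker inhibition), compound 1 gives 0.58 ug/mL, the lower of the numbers so far, and compound 2 follows at 1.58 ug/mL. Compound 3 differs from compound 1 in one place: hydrogen in place of methyl on an aromatic carbon. Put simply, hydrogen takes the place of methyl on an aromatic carbon, turning 4-methylphenyl into phenyl.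

Among the measured compounds shown here, no measured pair shows this exact change. For the measured compounds named here, the only evidence is a 2.7-fold higher number from compound 1 to compound 2 (0.44 log units; beyond the scatter), a modest step that puts hydrogen in place of methoxy on an aromatic carbon. It involves a different group, so it is only a loose guide to size and says little about direction. It does show that one such swap on compound 1 can move the number modestly, and that the swap tested made it higher.

A small rise in this assay is therefore expected, probably within the scatter. The estimated change is a 1.4-fold higher number from compound 1 to compound 3 (0.14 log units; within the scatter). For compound 3 the expected value is 0.8 ug/mL, with an estimated range of 0.3 ug/mL to 2 ug/mL.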

Compound 3, half-maximal inhibitory concentration: 0.68 ug/mL
The estimate for compound 3 lay 1.2-fold (0.07 log units) above the measured number; the measured number falls inside the stated range.
By their numbers in this assay, from the lowest: compounds 1 and 3 (each within the scatter of the next); then compound 2.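

In this assay, turning 4-methylphenyl into phenyl gives a step that stays within the usual scatter (a 1.2-fold higher number from compound 1 to compound 3 (0.07 log units; within the scatter)), so this methyl can be replaced by hydrogen with no detectable effect on the number. Among these compounds, the earlier compounds could not show this, as their only step (a 2.7-fold higher number from compound 1 to compound 2 (0.44 log units; beyond the scatter)) concerned methoxy rather than methyl, and it lay beyond the scatter. Together, the two steps show that on compound 1, replacing methoxy with hydrogen moves the number measurably, whereas replacing this methyl with hydrogen does not, and no supporting evidence is available to explain the difference.

Only methyl and hydrogen appear at this place among the compounds shown, which leaves open what an amine, a carboxylic acid or a longer chain such as propyl would do there. Among the compounds shown here, also open is whether methoxy would make the same difference in a compound carrying phenyl rather than 4-methylphenyl, since its step has been seen only with the methyl present.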